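Removing One Chloro Group from a Dichlorophenyl Ring

The source may report more compounds than this note shows. Statements on the series, on what has been measured and on what is new or still open speak of the compounds shown alone.

Compound 2 `COc1ccc(-c2nc(C)c(C(=O)CSc3nc(-c4ccc(Cl)c(Cl)c4)c(C#N)c(=O)[nH]3)s2)cc1` gives 88.6% in a functional assay on U-87MG ATCC cells for antiproliferative activity against U-87 MG (Homo sapiens), read by MTT assay, with a stated time of 48 h, tested at 10 uM; a lower number here means a stronger effect, a higher number a weaker effect of the compound at the concentration tested. This is the second highest of the three numbers measured; its nearest neighbour is compound 1 `Cc1nc(-c2ccc(Cl)cc2)sc1C(=O)CSc1nc(-c2ccc(Cl)c(Cl)c2)c(C#N)c(=O)[nH]1`, which gives 97.1%, and the step of a number 8.5 percentage points lower from compound 1 to compound 2 (within the scatter) lies within the scatter, so the two count as alike. Compound 3 `COc1ccc(-c2nc(SCC(=O)c3sc(-c4ccc(Cl)cc4)nc3C)nc(N)c2C#N)cc1` gives 64.5%, clearly below both. Compound 4 `COc1ccc(-c2nc(C)c(C(=O)CSc3nc(-c4cccc(Cl)c4)c(C#N)c(=O)[nH]3)s2)cc1` differs from compound 2 only by hydrogen in place of chloro on an aromatic carbon. Among the measured compounds shown here, no measured step touches this ring; the one step available, a number 8.5 percentage points lower from compound 1 to compound 2 (within the scatter), concerns a different ring and stayed within the scatter. Compound 4 is therefore expected to show a step of a number 0.6 percentage points lower from compound 2 to compound 4 (within the scatter), not beyond the scatter. Compound 4 is estimated at 88%, between 74% and 100%.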

Compound 4, a percentage reported as activity, at one concentration (the size of the read-out at that concentration, not a potency): 90.6%
Beside the measured number, compound 4's estimate is 2.6 percentage points below it; the measured number falls inside the stated range.
By their numbers in this assay, from the lowest: compound 3; then compounds 2, 4 and 1 (each within the scatter of the next).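

Unlike the earlier step, this one touches the ring that carries the chloro groups: going from 3,4-dichlorophenyl to 3-chlorophenyl gives, in this assay, a number 2 percentage points higher from compound 2 to compound 4 (within the scatter). With this one change, the two compounds count as alike, so losing this chloro group leaves the read-out within the usual scatter. No evidence here offers an explanation for this result.

From the compounds shown here alone, whether the remaining chloro group can also give way to hydrogen stays open. So does what an amine or a carboxylic acid would do at the place of the lost chloro group.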